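The source may hold more compounds than are shown below. What is called first, only, known or untested is meant among the compounds shown, and "the series" means these compounds.

Of the compounds shown here, three have been measured in a functional assay on cells (Cancer cell lines, Homo sapiens) for cytotoxicity, read by sulforhodamine B assay, with a stated time of 48 h; a higher number here means a weaker inhibitor of growth, a lower number a stronger inhibitor of growth. Compound 1 `COc1ccc(C2=NN(C3=NC(=O)/C(=C4\C(=O)Nc5ccccc54)S3)C(c3ccc(OC)cc3)C2)cc1` gives 100000 nM. Compound 2 `COc1ccc(C2=NN(C3=NC(=O)/C(=C4\C(=O)Nc5ccc(Br)cc54)S3)C(c3ccc(OC)cc3)C2)cc1` differs from it by bromo in place of hydrogen on an aromatic carbon, and in this assay compound 2 gives 25300 nM, so that a 4.0-fold lower number from compound 1 to compound 2 (0.60 log units; beyond the scatter). Compound 3 `COc1ccc(C2CC(c3ccc4ccccc4c3)=NN2C2=NC(=O)/C(=C3\C(=O)Nc4ccccc43)S2)cc1` carries a different core; the two cores differ by naphthalen-2-yl in place of 4-methoxyphenyl on a carbon with a double bond to nitrogen. In this assay compound 3 gives 12400 nM, so that an 8.1-fold lower number from compound 1 to compound 3 (0.91 log units; beyond the scatter). Compound 3 thus holds the lowest number of the three measured compounds.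

Compound 4 `COc1ccc(C2CC(c3ccc4ccccc4c3)=NN2C2=NC(=O)/C(=C3\C(=O)Nc4ccc(Br)cc43)S2)cc1` has not yet been measured. It differs from compound 3 by bromo in place of hydrogen on an aromatic carbon. The place of this change is described in the same words as for the change from compound 1 to compound 2, so the same change is made a second time, here on the core of compound 3. Whether the step repeats on this core is not known from these data. Resting on a 4.0-fold lower number from compound 1 to compound 2 (0.60 log units; beyond the scatter), compound 4 is expected to show a step of a 3.1-fold lower number from compound 3 to compound 4 (0.49 log units; beyond the scatter), taken a little smaller than the earlier one since the core is a different one. The estimate for compound 4 in this assay is 4000 nM, with a range from 1500 nM to 12000 nM.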

Compound 4, concentration for total growth inhibition: 140 nM
The estimate for compound 4 lay 29-fold (1.46 log units) above the measured number; measured number below the stated range.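

In this assay the bromo change gives an 89-fold lower number from compound 3 to compound 4 (1.95 log units; beyond the scatter) on the core of compound 3, a much larger step than on the core of compound 1: the same change on two cores in this assay, a 4.0-fold lower number (0.60 log units; beyond the scatter) from compound 1 to compound 2 and an 89-fold lower number (1.95 log units; beyond the scatter) from compound 3 to compound 4, 22-fold (1.35 log units) apart, beyond the scatter of two such steps. Read the other way round, the change to naphthalen-2-yl gives a 180-fold lower number from compound 2 to compound 4 (2.26 log units; beyond the scatter) when the bromo is present, again larger than the earlier step: the same change on two cores in this assay, an 8.1-fold lower number (0.91 log units; beyond the scatter) from compound 1 to compound 3 and a 180-fold lower number (2.26 log units; beyond the scatter) from compound 2 to compound 4, 22-fold (1.35 log units) apart, beyond the scatter of two such steps. Each change thus lowers the number on both cores, but its size depends on the other change, so the two do not simply add; these four compounds show this for one pair of changes only and do not show why the steps differ.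

The compounds shown leave open whether a chloro group or an amine in place of the bromo would give a step of the same size on the core of compound 3. They also leave open whether the large step would persist with a plain phenyl in place of naphthalen-2-yl.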